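The compounds below may be only part of what the source reports. "The series", "measured", "known", "first", "only" and "open" are said of these compounds alone.

Compound 1 `O=[N+]([O-])c1c(CS(=O)(=O)c2ccccc2)nc2c(-c3ccc(Cl)cc3)cc(Cl)cn12` is held at a limit of an ADME assay on HepG2 cells (Homo sapiens) for cytotoxicity, read by MTT assay, with a stated time of 72 h; a higher number here means that more compound is tolerated, a lower number that less compound is tolerated: > 3900 nM. Compound 2 `COc1ccc(-c2cc(Cl)cn3c([N+](=O)[O-])c(CS(=O)(=O)c4ccccc4)nc23)cc1` likewise sits at a limit in this assay: > 3900 nM.

Compound 2 therefore stands at a limit of the assay rather than at a number. For the measured compounds named here, the single step between the two measured compounds, a step that the two limits leave unreadable from compound 1 to compound 2, cannot be read in size or direction, because of the limit of > 3900 nM in this assay, at which 2 of the 2 values shown sit. Going by the values given here, no measured step therefore bears on the next change with a readable size.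

Compound 3 `O=[N+]([O-])c1c(CS(=O)(=O)c2ccccc2)nc2c(-c3cccnc3)cc(Cl)cn12` differs from compound 2 by pyridin-3-yl in place of 4-methoxyphenyl on an aromatic carbon. Among the compounds with values here, with no readable step to draw on, the only guide is that both measured compounds rest at the same limit, so the expectation for compound 3 is that it too lies at or beyond that limit, a step that the limit leaves unreadable from compound 2 to compound 3 that is expected to stay within the scatter. Compound 3 is therefore estimated at 5000 nM, in the range 3000 nM to 20000 nM.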

Compound 3, half-maximal cytotoxic concentration: > 31300 nM
Compound 3 ended at the assay's limit; the forecaster's own chance of this, stated with the estimate: 85%; at least 6.2-fold (0.79 log units) between middle value and limit.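

The steps from compound 1 and from compound 2 to compound 3 cannot be read, because all three compounds rest at limits in this assay: the limit of > 3900 nM in this assay, at which 2 of the 3 values shown sit.

The compounds shown leave open at what concentration each becomes toxic to these cells, and whether swapping the aromatic group on the shared core changes how much compound is tolerated.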